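A few compounds are considered here, and "the series" means these few. Any claim that something is new, unique, unknown or untested is made for them only; others in the source may bear on it.

Compound 1 `Cc1ccc(Nc2nc(C)c(C(=O)/C=C/c3ccc(Cl)cc3)s2)cc1`: > 25000 nM
Compound 2 `Cc1nc(Nc2ccc(Cl)c(Cl)c2)sc1C(=O)/C=C/c1ccc(Cl)cc1`: 22700 nM

Both share the shared core and differ only in the ring on the aromatic nitrogen. In a functional assay on BGC-823 cells (Homo sapiens) for cytotoxicity, read by MTT assay (a higher number here means a weaker inhibitor, a lower number a stronger inhibitor), compound 1 gives > 25000 nM, which is a limit of the assay and not a number (the limit of > 25000 nM in this assay, at which 1 of the 2 values shown sits). In this assay compound 2 gives 22700 nM, the only number shown. The step of an at least 1.1-fold lower number from compound 1 to compound 2 (0.04 log units; that floor lies within the scatter) lies within the scatter. Compound 3 `Cc1cccc(Nc2nc(C)c(C(=O)/C=C/c3ccc(Cl)cc3)s2)c1` carries 3-methylphenyl in place of 3,4-dichlorophenyl on a nitrogen on an aromatic ring. Among the compounds with values here, only the step from compound 1 to compound 2 bears on this change, and it stayed within the scatter, so no movement beyond the scatter is expected in this assay. Compound 3 is expected to give 25000 nM (range 8000 nM to 80000 nM). That estimate means a step of a 1.1-fold higher number from compound 2 to compound 3 (0.04 log units; within the scatter).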

Compound 3, half-maximal inhibitory concentration: > 25000 nM
Compound 3: only a limit was reported (the forecaster's own chance of this, stated with the estimate: 50%); the middle value sits exactly at the limit.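

In this assay, putting 3-methylphenyl in place of 3,4-dichlorophenyl on the nitrogen gives a small step (an at least 1.1-fold higher number from compound 2 to compound 3 (0.04 log units; that floor lies within the scatter)). Going by these compounds, compound 3 reports only a limit, so that step is a floor and its true size stays unknown. The step from compound 1 to compound 3 cannot be read, and most values here rest at one ceiling: the limit of > 25000 nM in this assay, at which 2 of the 3 values shown sit.

Still open, on these data alone, is how this assay would read an amine or a carboxylic acid on this ring, or a longer chain in place of the ring, and whether either would give a number clear of that limit.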